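Trimming a methoxy from the unprotected glycoside ester

The source may report more compounds than this note shows. Statements on the series, on what has been measured and on what is new or still open speak of the compounds shown alone.

Compound 2 `C/C=C1/[C@H](O[C@@H]2O[C@H](CO)[C@@H](O)[C@H](O)[C@H]2O)OC=C(C(=O)OC)[C@H]1CC(=O)OCCc1ccc(OC)c(OC)c1` carries a free sugar and a 2-(3,4-dimethoxyphenyl)ethyl ester on the shared core. In a functional assay on SK-BR-3 cells (Homo sapiens) for antiproliferative activity, read by MTT assay, with a stated time of 72 h (a lower number here means a stronger inhibitor, a higher number a weaker inhibitor), compound 2 returns only a limit, > 15000 nM. Compound 1 `C/C=C1/[C@H](O[C@@H]2O[C@H](COC(C)=O)[C@@H](OC(C)=O)[C@H](OC(C)=O)[C@H]2OC(C)=O)OC=C(C(=O)OC)[C@H]1CC(=O)OCCC`, with a peracetylated sugar and a propyl ester, gives 6600 nM in this assay. Compound 3 `C/C=C1/[C@H](O[C@@H]2O[C@H](COC(C)=O)[C@@H](OC(C)=O)[C@H](OC(C)=O)[C@H]2OC(C)=O)OC=C(C(=O)OC)[C@H]1CC(=O)OCCC1CCCCC1` also reaches only a limit in this assay, > 15000 nM. Going by the values given here, the single step between neighbours, an at least 2.2-fold higher number from compound 1 to compound 3 (0.35 log units; beyond the scatter), leads to the ceiling of the assay, because of the limit of > 15000 nM in this assay, at which 2 of the 3 values shown sit.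

Compound 4 `C/C=C1/[C@H](O[C@@H]2O[C@H](CO)[C@@H](O)[C@H](O)[C@H]2O)OC=C(C(=O)OC)[C@H]1CC(=O)OCCc1ccc(OC)cc1` differs from compound 2 by hydrogen in place of methoxy on an aromatic carbon; in the wider view, 2-(3,4-dimethoxyphenyl)ethyl becomes 2-(4-methoxyphenyl)ethyl. Among the compounds with values here, no measured step touches the aromatic ester, so nothing bears directly on this change; the only step seen concerns a different ester and is at least modest. Compound 2 stands at the ceiling. Compound 4 is expected to remain near that ceiling, an expected step of a number no higher from compound 2 to compound 4 (the limit leaves the size open). Compound 4 is therefore estimated at 15000 nM, between 5000 nM and 40000 nM, and most probably reported again only as a limit.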

Compound 4, half-maximal inhibitory concentration: > 20000 nM
Compound 4: a limit, no number; the forecaster's own chance of this, stated with the estimate: 70%; at least 1.3-fold (0.12 log units) between middle value and limit.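

In this assay compound 4 returns only a limit, > 20000 nM. Compound 2 is also recorded only as a limit, so no step can be read between compound 2 and compound 4. The compounds shown leave open whether losing this methoxy changes activity at all, and in which direction.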